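Piperidine substituent swap: methoxy to carbamoyl

The source may hold more compounds than are shown below. What is called first, only, known or untested is meant among the compounds shown, and "the series" means these compounds.

Going by the values given here, compound 2 `COc1cc(COc2cc(N)c(Cl)cc2C(=O)CCCCN2CCC(OC)CC2)cc(OC)c1` holds the higher of the two numbers available so far. In a functional assay for antagonist activity at 5-hydroxytryptamine receptor 4 (Rattus norvegicus) (on this read-out lower numbers stand for lower potency and higher numbers for higher potency (the scale is a negative logarithm)), compound 2 gives 8.4, and compound 1 `COc1cc(COc2cc(N)c(Cl)cc2C(=O)CCCCN2CCC(c3ccccc3)CC2)cc(OC)c1` gives 7.7. Among the compounds with values here, the one recorded step, a number 0.70 log units higher from compound 1 to compound 2 (beyond the scatter), is the only guide to what the group on the saturated ring carbon does.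

Compound 3 `COc1cc(COc2cc(N)c(Cl)cc2C(=O)CCCCN2CCC(C(N)=O)CC2)cc(OC)c1` has not been measured. It differs from compound 2 in this way: carbamoyl in place of methoxy on a saturated ring carbon. Within the data shown here, the change sits at the same saturated ring carbon as the step from compound 1 to compound 2, but no step exchanges methoxy for carbamoyl, so that step bears on it only by place, not by kind of group. With a single modest step as reference, the working expectation for compound 3 is a step of about a number 0.20 log units lower from compound 2 to compound 3 (within the scatter), which is within the usual scatter; no movement beyond the scatter is expected in either direction. Compound 3 is therefore estimated at 8.2, with a range from 7.4 to 9.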

Compound 3, negative logarithm of the antagonist equilibrium constant: 8.4
Compound 3: the middle estimate sits 0.20 log units below what was measured; low and high end bracket the measured number.
By their numbers in this assay, from the lowest: compound 1; then compounds 2 and 3 (each within the scatter of the next).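

On the saturated ring carbon three ring bonds from the ring nitrogen, 4-methoxypiperidin-1-yl and 4-carbamoylpiperidin-1-yl cannot be told apart in this assay, with no change at the digits printed from compound 2 to compound 3 (within the scatter), although the two groups differ in heavy atoms and in hydrogen-bond donors as counted. Going by these compounds alone, the step to carbamoyl from phenyl reads a number 0.70 log units higher from compound 1 to compound 3 (beyond the scatter) and matches a number 0.70 log units higher from compound 1 to compound 2 (beyond the scatter), so among the three compounds the separation at this position lies between phenyl on one side and the two groups without a ring on the other, with no compound going against that reading. Nothing available here accounts for either the shared level of compounds 2 and 3 or the gap to compound 1.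

The compounds shown leave open whether a carboxylic acid, a primary amine or a hydroxyl on the same ring carbon would stay level with compounds 2 and 3 or fall toward compound 1 in this assay. Also open, on these data alone, is whether methylcarbamoyl or dimethylcarbamoyl would hold that level, and whether cyclohexyl in place of phenyl would show the gap to follow the ring as such or the phenyl group in particular.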